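A few compounds are considered here, and "the series" means these few. Any claim that something is new, unique, unknown or untested is made for them only; others in the source may bear on it.

The series is followed in an assay on Sf9 cells for inhibition of protein deacetylase HDAC6 (Homo sapiens), read by fluorescence; a higher number here means a weaker inhibitor, a lower number a stronger inhibitor. Compound 1 `O=C(NO)c1ccc(Cn2nnc(Cc3ccccn3)n2)cc1` gives 25 nM in this assay. Compound 2 `Cn1c(Sc2c(F)cc(C(=O)NO)cc2F)nnc1-c1cccc(CN2CCCCCC2)c1` gives 10 nM in this assay, a lower number than that of compound 1 by a gap that lies beyond the scatter; of the two measured numbers, compound 1 thus stands as the higher one. Within the data shown here, the two compounds differ in many places at once, so no single step connects them and their values show only that the set spans this gap.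

Compound 3 `O=C(NO)c1ccc(Cn2nnc(-c3ccccc3)n2)cc1` has not yet been measured. It differs from compound 1 in one place: phenyl in place of (pyridin-2-yl)methyl on an aromatic carbon. The hydroxamic acid part and the rest of the core of compound 1 are unchanged; only the group on that ring carbon of the five-membered aromatic ring with four nitrogen atoms is exchanged. Among the measured compounds shown here, no measured pair in this set isolates such an exchange, so the size of the step is open. The expectation is a step from compound 1 to compound 3 of a 1.2-fold higher number from compound 1 to compound 3 (0.08 log units; within the scatter), within the scatter or only just beyond it, with no firm direction. Compound 3 is accordingly expected to give about 30 nM in this assay, with a range from 8 nM to 120 nM.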

Compound 3, half-maximal inhibitory concentration: 3 nM
For compound 3 the middle estimate is 10-fold (1.00 log units) above the measured one; the measured number lies below the stated range.
By their numbers in this assay, from the lowest: compound 3; then compound 2; then compound 1.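

Working from this assay, the ring carbon bearing this group, on the five-membered aromatic ring with 4 nitrogen, is now shown to be a place where a single exchange matters: phenyl in place of (pyridin-2-yl)methyl gives an 8.3-fold lower number from compound 1 to compound 3 (0.92 log units; beyond the scatter), the first step in the series that isolates one change, and it lies beyond the scatter. The exchange alters two things at once, since phenyl lacks both the methyl link to the ring and the ring nitrogen of the pyridine, so this step alone cannot assign the shift to either feature. Among these compounds, nothing measured so far bears on why the number falls with this exchange.

Still open, going by these compounds, is which of the two features carries the step: benzyl on the same ring carbon would keep the link without the ring nitrogen, and pyridin-2-yl would keep the ring nitrogen without the link. Also open, on these data alone, is how far the phenyl ring tolerates further groups, such as a methoxy group, a fluorine or an amine, and whether a plain methyl on that carbon holds any of the step.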